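Dichlorophenyl in place of phenyl on the shared core

The compounds below may be only part of what the source reports. "The series", "measured", "known", "first", "only" and "open" are said of these compounds alone.

Measured compounds:
compound 1 `O=C(CCCc1ccccc1)Nc1nc2ccsc2c(=O)s1` — 547 nM
compound 2 `O=C(CCc1ccccc1)Nc1nc2ccccc2c(=O)s1` — 365 nM
compound 3 `O=C(C/C=C/c1cccc(Cl)c1)Nc1nc2ccccc2c(=O)s1` — > 1000 nM

In an assay on CHO cells for displacement of a labelled ligand from adenosine receptor A2b (Homo sapiens), read by scintillation counting, with a stated time of 75 min (a higher number here means a weaker inhibitor, a lower number a stronger inhibitor), compound 2 gives 365 nM. Compound 1, which carries a different core and a longer chain, gives 547 nM in this assay, and the two values lie within the usual scatter of each other, so no order can be read between them. Compound 3 gives only a limit in this assay, > 1000 nM, and so stands apart from the two numbers. Among the numbers actually measured, compound 2 therefore sits at the level of compound 1 and not separated from it.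

Compound 4 `O=C(CCc1ccc(Cl)c(Cl)c1)Nc1nc2ccccc2c(=O)s1` has not been measured. It differs from compound 2 by 3,4-dichlorophenyl in place of phenyl on a saturated chain carbon, two bonds along the chain from a carbonyl carbon. Among the measured compounds shown here, no pair among the measured compounds differs in that place alone, so there is no measured step to rest an expectation on. For the measured compounds named here, compound 3, the only measured compound bearing a chlorine on its ring, also differs in its chain and gives only a limit, so it does not settle the question either way. The step from compound 2 to compound 4 is expected to be small, a 1.2-fold lower number from compound 2 to compound 4 (0.09 log units; within the scatter), and not clearly beyond the scatter. Compound 4 is estimated at 300 nM, within a range from 100 nM to 1000 nM.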

Compound 4, inhibition constant: > 1000 nM
Compound 4 gave a limit, no number; the forecaster's own chance of this, stated with the estimate: 15%; middle value at least 3.3-fold (0.52 log units) away from the limit.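

The change from phenyl to 3,4-dichlorophenyl on a saturated chain carbon, two bonds along the chain from a carbonyl carbon, now has a measured step in this assay: it is an at least 2.7-fold higher number from compound 2 to compound 4 (0.43 log units; beyond the scatter). Compound 3 also carries chlorine on its ring but differs in its chain as well, so it could not show this; compound 2 and compound 4 differ in this one place alone, and the weaker inhibition can be tied to this change of ring on the shared core. Compound 4 gives a limit and not a number, so the step has a lower bound but no measured size: the limit of > 1000 nM in this assay, at which 2 of the 4 values shown sit.

The compounds shown leave open whether a single chlorine, a fluorine or a methoxy group on the same ring would also weaken inhibition, and whether both chlorines are needed for the step. Also open, on these data alone, is whether the same change would have a similar outcome on the core of compound 1 or on the longer chain that compound 1 carries.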